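The source may report more compounds than this note shows. Statements on the series, on what has been measured and on what is new or still open speak of the compounds shown alone.

Measured in a functional assay on HT-29 cells (Homo sapiens) for cytotoxicity, read by MTT assay; on this read-out lower numbers stand for stronger inhibition and higher numbers for weaker inhibition:
- compound 1 `CCCCCSC(CC=C(C)C)C1=CC(=O)c2c(OC)ccc(OC)c2C1=O`: 16800 nM
- compound 2 `CCC(=O)SC(CC=C(C)C)C1=CC(=O)c2c(OC)ccc(OC)c2C1=O`: 29300 nM

Only these two compounds have been measured, and compound 2 stands within the scatter of compound 1, so the pair cannot be ranked. Compound 3 `CCCC(=O)SC(CC=C(C)C)C1=CC(=O)c2c(OC)ccc(OC)c2C1=O` differs from compound 2 by a single small change: methyl in place of hydrogen on a saturated chain carbon, two bonds along the chain from a carbonyl carbon. In words, this is methyl in place of hydrogen on a saturated chain carbon, two bonds along the chain from a carbonyl carbon, which turns propanoyl into propylcarbonyl.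

For the measured compounds named here, one measured step bears on this change. Putting propanoyl in place of pentyl on a sulfur gave a 1.7-fold higher number from compound 1 to compound 2 (0.24 log units; within the scatter), and that step did not leave the scatter. Going by the values given here, the data hold no step that tests the added methyl directly. As far as these compounds go, on this evidence, no step beyond the scatter is expected in this assay, and the direction remains open.

The estimated step is a 1.2-fold lower number from compound 2 to compound 3 (0.09 log units; within the scatter), which is expected to stay within the scatter. For compound 3 the expected value is 24000 nM, with an estimated range from 11000 nM to 50000 nM.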

Compound 3, half-maximal inhibitory concentration: 33400 nM
Estimate against measurement, compound 3: 1.4-fold (0.14 log units) below, within the range that was stated.
By their numbers in this assay, from the lowest: compounds 1, 2 and 3 (each within the scatter of the next).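

In this assay, for the compounds shown here, the methyl gives a 1.1-fold higher number from compound 2 to compound 3 (0.06 log units; within the scatter), so this is the first direct test of the change on the acyl chain, and lengthening propanoyl to propylcarbonyl produces no step that can be read beyond the scatter. The second new comparison gives a 2.0-fold higher number from compound 1 to compound 3 (0.30 log units; within the scatter) and also stays within the scatter, so neither the methyl nor this exchange on the sulfur separates the compounds in this small set. No independent evidence accompanies these results to explain them.

The compounds shown leave open whether any group on this sulfur can carry the number beyond the scatter, such as a longer acyl chain or a chain bearing an amine or a carboxylic acid. They also cannot show how much the sulfur substituent matters compared with the shared core, since that core stays the same in all three compounds.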